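Working notes: vinyl to phenyl on the shared core

A few compounds are considered here, and "the series" means these few. Any claim that something is new, unique, unknown or untested is made for them only; others in the source may bear on it.

Measured in an ADME assay on HEK293 cells (Homo sapiens) for cytotoxicity, read by luminescence, with a stated time of 72 h; a higher number here means that more compound is needed for the effect, a lower number that less compound is needed:
- Compound 1 `CCOC(=O)c1c(-c2cccc(C)c2)[nH]c2cc(OC)ccc2c1=O`: > 22000 nM (a limit)
- Compound 2 `C=Cc1cccc(-c2[nH]c3cc(OC)ccc3c(=O)c2C(=O)OCC)c1`: > 22000 nM (a limit)

Compound 2 stands at > 22000 nM, and this is a limit of the assay, not a number. The only reference point so far is the limit of > 22000 nM in this assay, at which 2 of the 2 values shown sit. The next compound, compound 3 `CCOC(=O)c1c(-c2cccc(-c3ccccc3)c2)[nH]c2cc(OC)ccc2c1=O`, carries phenyl in place of vinyl on an aromatic carbon.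

Among the compounds with values here, one measured step bears on this change, as it involves the same substituent: a step that the two limits leave unreadable from compound 1 to compound 2. It has no readable size, so it gives no measure of how far a change of this group can move this assay. Within the data shown here, with that step as the only guide, no step beyond the scatter is expected, and no direction can be favoured. Among the measured compounds shown here, the data include no measured example with a phenyl group in this place, so this expectation is weakly supported. A further report of a limit is considered the likeliest outcome. The estimated step is a number no higher from compound 2 to compound 3 (the limit leaves the size open). For compound 3 the expected value is 22000 nM, within an estimated range of 10000 nM to 45000 nM.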

Compound 3, half-maximal effective concentration: > 22000 nM
Compound 3 was reported as a limit (the forecaster's own chance of this, stated with the estimate: 80%); the middle value sits exactly at the limit.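

No new step can be read for compound 3 against compound 1 or compound 2, as each value is a limit of the assay and not a number: the limit of > 22000 nM in this assay, at which 3 of the 3 values shown sit.

The compounds shown leave open whether methyl, vinyl or phenyl on this aromatic carbon differ at all in this assay, and what concentration any of the three would need for the effect.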